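A few compounds are considered here, and "the series" means these few. Any claim that something is new, unique, unknown or untested is made for them only; others in the source may bear on it.

Measured in a functional assay on MCF7 cells (Homo sapiens) for antiproliferative activity, read by MTT assay; a lower number here means a stronger inhibitor, a higher number a weaker inhibitor:
Compound 1 `Cc1c(C)c2c(c(C)c1OC(=O)[C@@H](N)CCCCN)CC[C@@](C)(CCC[C@H](C)CCC[C@H](C)CCCC(C)C)O2`: 12000 nM
Compound 2 `Cc1c(C)c2c(c(C)c1OC(=O)[C@@H](N)CCCCN)CCC(C)(CO)O2`: 194000 nM

Of these two, compound 2 has the higher number and is the weaker inhibitor. Compound 3 `CCCCCOCC1(C)CCc2c(C)c(OC(=O)[C@@H](N)CCCCN)c(C)c(C)c2O1` differs from it by pentyl in place of hydrogen on an oxygen on a saturated carbon, with pentyl in place of hydrogen on an oxygen on a saturated carbon, so that hydroxymethyl becomes (pentyloxy)methyl. Among the compounds with values here, no measured step shows this change on its own. Within the data shown here, the only other reference is compound 1 at 12000 nM, so a moderate fall in this assay towards that value is expected. The expected change is a 3.9-fold lower number from compound 2 to compound 3 (0.59 log units; beyond the scatter). Compound 3 is estimated at 50000 nM, with an expected range of 15000 nM to 150000 nM.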

Compound 3, half-maximal inhibitory concentration: 22000 nM
For compound 3 the middle estimate is 2.3-fold (0.36 log units) above the measured one, within the range that was stated.
By their numbers in this assay, from the lowest: compounds 1 and 3 (each within the scatter of the next); then compound 2.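

In this assay, replacing the hydrogen on this oxygen with pentyl gives an 8.8-fold lower number from compound 2 to compound 3 (0.95 log units; beyond the scatter) and turns hydroxymethyl into (pentyloxy)methyl. Within the data shown here, this is the first single change read at this position, and it shows that the oxygen on a saturated carbon accepts a pentyl group without loss of activity. Nothing available explains why the number falls.

From the compounds shown here alone, whether a methyl group, a longer chain, an amine or a carboxylic acid at this oxygen would give a similar step remains open. So does whether the step comes from the pentyl chain itself or from capping the hydroxy group.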